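Acetamido in Place of Hydroxy: Expected Toxicity of Compound 4

The compounds below may be only part of what the source reports. "The series", "measured", "known", "first", "only" and "open" are said of these compounds alone.

Of the compounds shown here, three on a shared core have been tested in a functional assay on RD cells (Homo sapiens) for inhibition, read by luminescence and ATP content, with a stated time of 72 h; on this read-out higher numbers stand for lower toxicity in this test and lower numbers for higher toxicity in this test. Compound 1 `CCCc1ccc(-c2ccc3ncc(-c4noc(CC)n4)cc3c2)cc1` carries a propyl group, and in this assay compound 1 reaches only a limit of > 7400 nM. Compound 2 `CCc1nc(-c2cnc3ccc(-c4ccccc4)cc3c2)no1` carries hydrogen in that place, and in this assay compound 2 likewise gives only the limit > 7400 nM. Compound 3 `CCc1nc(-c2cnc3ccc(-c4ccc(O)cc4)cc3c2)no1` carries a hydroxy group, and in this assay compound 3 gives a limit of > 2500 nM. The steps a step that the two limits leave unreadable from compound 1 to compound 2, a step that the two limits leave unreadable from compound 1 to compound 3 and a step that the two limits leave unreadable from compound 2 to compound 3 are all bounded by limits on both sides and yield no size. Compound 3 thus stands at the limit of > 2500 nM in this assay, at which 1 of the 3 values shown sits, whereas compounds 1 and 2 sit at the limit of > 7400 nM in this assay, at which 2 of the 3 values shown sit; none of the three is separated from another beyond the scatter.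

Compound 4 `CCc1nc(-c2cnc3ccc(-c4ccc(NC(C)=O)cc4)cc3c2)no1` differs from compound 3 by acetamido in place of hydroxy on an aromatic carbon. For the measured compounds named here, no measured step bears directly on this change, and the measured steps that exist are unreadable, so there is no ground to expect a step beyond the scatter in this assay in either direction. Compound 4 is therefore expected to give about 10000 nM in this assay, with a range from 3000 nM to 40000 nM, most probably again as a limit. This corresponds to an expected step that the limit leaves unreadable from compound 3 to compound 4.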

Compound 4, half-maximal cytotoxic concentration: > 7400 nM
Compound 4: only a limit was reported (the forecaster's own chance of this, stated with the estimate: 80%); the middle value lies beyond the limit too.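

In this assay compound 4 gives only a limit, > 7400 nM. For the compounds shown here, compound 1, compound 2 and compound 3 also stand at limits, so no step to compound 4 can be read. The compounds shown leave open where the toxicity of any of the four lies in this assay, and whether propyl, hydrogen, hydroxy or acetamido changes it at all.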